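The source may report more compounds than this note shows. Statements on the series, on what has been measured and on what is new or still open speak of the compounds shown alone.

Measured compounds:
Compound 1 `COc1cc(/C=C/C(=O)N2CCC=CS2(=O)=O)cc(OC)c1`, in a functional assay on HeLa cells (Homo sapiens) for inhibition, read by sulforhodamine B assay, with a stated time of 48 h; a lower number here means a stronger inhibitor of growth, a higher number a weaker inhibitor of growth: < 100 nM, a limit of the assay rather than a number.
Compound 2 `COc1cccc(/C=C/C(=O)N2CCC=CS2(=O)=O)c1`, in this assay: 23700 nM.

Among the measured compounds shown here, compound 2 stands as the only compound with a number in this assay; the further value shown is a limit. For compound 1 the value is the limit of < 100 nM in this assay, at which 1 of the 2 values shown sits, and that is all that can be said of it. Between the two compounds a single step is known: an at least 230-fold higher number from compound 1 to compound 2 (2.37 log units; beyond the scatter), a large weakening of growth inhibition when hydrogen takes the place of methoxy on an aromatic carbon.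

Compound 3 `Cc1cccc(/C=C/C(=O)N2CCC=CS2(=O)=O)c1` differs from compound 2 by methyl in place of methoxy on an aromatic carbon. For the measured compounds named here, the measured step speaks to taking a methoxy away altogether, not to exchanging it for methyl, so it bears only loosely on this change, and no step measures methoxy against methyl directly. For compound 3 the expected step is therefore small, either none beyond the scatter or a mild weakening: a 1.5-fold higher number from compound 2 to compound 3 (0.17 log units; within the scatter). The estimate for compound 3 in this assay is 35000 nM, with a range from 9000 nM to 130000 nM.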

Compound 3, concentration for 50% growth inhibition: 20700 nM
Estimate against measurement, compound 3: 1.7-fold (0.23 log units) above, within the range that was stated.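

In this assay, the exchange of methoxy for methyl on this aromatic carbon gives a 1.1-fold lower number from compound 2 to compound 3 (0.06 log units; within the scatter), so the two groups cannot be told apart here, although methoxy brings an oxygen and a hydrogen-bond acceptor and methyl brings neither. The earlier step showed only that taking a methoxy off compound 1 costs a great deal of growth inhibition; this new step shows that, with the other methoxy already gone, the oxygen at this remaining place makes no readable difference. Nothing shown gives a reason for this result.

As far as these compounds go, the comparison holds only in the weak range of compound 2 and compound 3, so it remains open whether methyl could also stand in for methoxy in the far stronger setting of compound 1. Also open, from the compounds shown here alone, is how the shared core would respond at this place to a group of another kind, such as an amine, a carboxylic acid or a longer chain.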